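The source may hold more compounds than are shown below. What is called first, only, known or untested is meant among the compounds shown, and "the series" means these compounds.

Measured so far:
- compound 1, `COc1cccc(S(=O)(=O)c2n[nH]c3ccc(N4CCN(C)CC4)cc23)c1`: 1.1 nM
- compound 2, `COc1ccc(S(=O)(=O)c2n[nH]c3cc(N4CCNCC4)ccc23)cc1`: 124 nM
- compound 3, `COc1ccc(S(=O)(=O)c2n[nH]c3cccc(N4CCNCC4)c23)cc1`: 88 nM

In an assay on HeLa cells for displacement of a labelled ligand from 5-hydroxytryptamine receptor 6 (Homo sapiens) (on this read-out lower numbers stand for stronger inhibition and higher numbers for weaker inhibition), compound 1 gives the lowest number of the three, and its gap to both compound 2 and compound 3 lies beyond the usual scatter; those two compounds differ from compound 1 in more than one place, so no single change can be read off from them.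

Compound 4, `CN1CCN(c2ccc3[nH]nc(S(=O)(=O)c4ccc(Cl)cc4)c3c2)CC1`, has not been measured. It differs from compound 1 by 4-chlorophenyl in place of 3-methoxyphenyl on a sulfonyl sulfur. For the measured compounds named here, no measured pair isolates this change, so the expectation rests on compound 1 alone. A modest weakening is expected, a 2.7-fold higher number from compound 1 to compound 4 (0.44 log units; beyond the scatter), which may well stay inside the scatter. Compound 4 is therefore estimated at 3 nM, within a range from 0.7 nM to 15 nM.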

Compound 4, inhibition constant: 8.1 nM
Compound 4: middle estimate off by 2.7-fold (0.43 log units), on the low side; measured number inside the range.
By their numbers in this assay, from the lowest: compound 1; then compound 4; then compounds 3 and 2 (each within the scatter of the next).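

In this assay, for the compounds shown here, putting 4-chlorophenyl in place of 3-methoxyphenyl on the sulfonyl sulfur gives a 7.4-fold higher number from compound 1 to compound 4 (0.87 log units; beyond the scatter), the first change in a single place in this set. The group on this sulfur therefore affects the number, though the step is modest and compound 4 still gives 8.1 nM. No available evidence explains this step.

The step swaps the substituent and also its ring position, so the two effects remain tangled. A 3-chlorophenyl group on the sulfonyl sulfur would separate them, while a plain phenyl would show what either substituent adds.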